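The source may hold more compounds than are shown below. What is called first, only, known or untested is meant among the compounds shown, and "the series" means these compounds.

Three compounds have been measured in an assay on SH-EP1 cells for agonist activity at Neuronal acetylcholine receptor; alpha4/beta2 (Homo sapiens), read by FLIPR and calcium flux; on this read-out higher numbers stand for an effect only at larger amounts of compound and lower numbers for an effect already at smaller amounts:

Compound 1, `O=C(C1CCC1)N1CC2CC(C1)N2`, gives 2900 nM.
Compound 2, `O=C(C1CCCC1)N1CC2CC(C1)N2`, gives 11000 nM.
Compound 3, `O=C(CC1C=CCC1)N1CC2CC(C1)N2`, gives 14000 nM.

Compound 1 stands at the lowest number of the three in this assay. The nearest to it is compound 2, whose number is higher by a margin beyond the usual scatter; compound 3 lies furthest, also beyond the scatter. Among the measured compounds shown here, no pair among the measured compounds differs in a single place, so none of these gaps can be tied to one structural change.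

Compound 4, `C[C@H]1C[C@@H]1C(=O)N1CC2CC(C1)N2`, is the next compound in line. Its difference from compound 1 is 2-methylcyclopropyl in place of cyclobutyl on a carbonyl carbon. The two compounds hold the same atoms, joined differently, and the carbonyl carbon keeps its amide-type nitrogen neighbour in the ring. For the measured compounds named here, no measured pair shows what a four-membered to three-membered ring exchange with a methyl does here, so the expected step in this assay is set at none beyond the scatter: the estimated change is a 1.2-fold lower number from compound 1 to compound 4 (0.06 log units; within the scatter). On that basis compound 4 is expected to give about 2500 nM in this assay, with a range from 800 nM to 8000 nM.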

Compound 4, half-maximal effective concentration: 9100 nM
Estimate against measurement, compound 4: 3.6-fold (0.56 log units) below; the measured number lies above the stated range.
By their numbers in this assay, from the lowest: compound 1; then compounds 4, 2 and 3 (each within the scatter of the next).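

In this assay there is now a step that can be tied to one structural change: 2-methylcyclopropyl in place of cyclobutyl on a carbonyl carbon gives a 3.1-fold higher number from compound 1 to compound 4 (0.50 log units; beyond the scatter) as its result. Both groups hold the same count of carbon atoms and neither carries a hydrogen-bond donor or acceptor, so this position responds to how those carbons are joined, not only to how many there are. Nothing at hand bears on why the number rises.

The compounds shown do not divide the step between the smaller ring and its methyl, and whether a plain cyclopropyl on the same carbonyl carbon would stay close to compound 1 remains open. Also open, on these data alone, is what the mirror-image 2-methylcyclopropyl, or an aminocyclobutyl, would give at this place.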